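Swapping Phenyl for Thiophene on a Dicarboxylic Acid Core

The compounds below may be only part of what the source reports. "The series", "measured", "known", "first", "only" and "open" are said of these compounds alone.

Compound 2 `O=C(O)c1cc2cc(-c3ccccc3)n(O)c2cc1C(=O)O` gives 56200 nM in an assay on isolated protein for inhibition of Amine oxidase [flavin-containing] B (Homo sapiens), read by fluorescence and spectrophotometry, with a stated time of 20 min (a lower number here means a stronger inhibitor, a higher number a weaker inhibitor), the weaker of the two measured compounds, while compound 1 `Cc1ccc(-c2cc3cc(C#N)c(C#N)cc3n2O)cc1` gives 821 nM in this assay. Compound 3 `O=C(O)c1cc2cc(-c3cccs3)n(O)c2cc1C(=O)O` keeps the core of compound 2 and changes one group: thiophen-2-yl in place of phenyl on an aromatic carbon. Within the data shown here, no measured pair shows this change, so the data say nothing about its effect. Replacing one small aromatic ring by a similar one is expected to move the number little, and the step of a 1.4-fold lower number from compound 2 to compound 3 (0.15 log units; within the scatter) is expected to stay within the usual scatter. Compound 3 is therefore estimated at 40000 nM, between 15000 nM and 150000 nM.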

Compound 3, half-maximal inhibitory concentration: > 100000 nM
Compound 3 ended at the assay's limit (the forecaster's own chance of this, stated with the estimate: 20%); at least 2.5-fold (0.39 log units) between middle value and limit.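

In this assay compound 3 gives > 100000 nM, which is a limit of the assay and not a number. The change reads as an at least 1.7-fold higher number from compound 2 to compound 3 (0.25 log units; that floor lies within the scatter), so thiophen-2-yl in place of phenyl, on this aromatic carbon next to the ring nitrogen, brings no gain in inhibition. The full size of the step cannot be read because the value stops at a limit: the limit of > 100000 nM in this assay, at which 1 of the 3 values shown sits.

On these data alone, what an amine or a longer chain would do at this position stays open. So does how thiophen-2-yl would read on the core of compound 1.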